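The source may hold more compounds than are shown below. What is called first, only, known or untested is meant among the compounds shown, and "the series" means these compounds.

Measured compounds in a functional assay on LOX IMVI cells (Homo sapiens) for inhibition, read by sulforhodamine B assay, with a stated time of 48 h; on this read-out higher numbers stand for weaker inhibition of growth and lower numbers for stronger inhibition of growth:
compound 1 `COc1cc(-c2nn(-c3cccc(NC(=O)c4cccc(C(F)(F)F)c4)c3)cc2-c2ccncc2)ccc1Cl` gives 1390 nM
compound 2 `COc1cc(-c2nn(-c3cccc(NC(=O)Nc4cccc(C(F)(F)F)c4)c3)cc2-c2ccncc2)ccc1Cl` gives 789 nM

Within the data shown here, compound 2 holds the lowest of the two numbers, but its only neighbour is compound 1, and the gap a 1.8-fold lower number from compound 1 to compound 2 (0.25 log units; within the scatter) lies within the scatter, so no order between the two is claimed.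

Compound 3 `COc1cc(-c2nn(-c3cccc(NC(=O)c4ccc(Cl)c(C(F)(F)F)c4)c3)cc2-c2ccncc2)ccc1Cl` is not yet measured. Against compound 2 the change is 4-chloro-3-(trifluoromethyl)phenyl in place of (3-(trifluoromethyl)phenyl)amino on a carbonyl carbon. Among the measured compounds shown here, the step brings back the aryl amide of compound 1 and adds a chloro group on that ring, so the one measured step that bears on it is the one from the amide to the urea, which went a 1.8-fold lower number from compound 1 to compound 2 (0.25 log units; within the scatter) and stayed within the scatter. Its reverse therefore gives no reason to expect a step beyond the scatter in this assay; for the added chloro there is no measured step at all, so the expectation rests on compound 1 and compound 2 alone. For compound 3 the expected step is a 1.4-fold higher number from compound 2 to compound 3 (0.14 log units; within the scatter), a number near that of compound 1, with wide bounds. Compound 3 is estimated at 1100 nM, between 400 nM and 3000 nM.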

Compound 3, concentration for 50% growth inhibition: 1920 nM
Beside the measured number, compound 3's estimate is 1.7-fold (0.24 log units) below it; the range from low to high includes it.
By their numbers in this assay, from the lowest: compounds 2, 1 and 3 (each within the scatter of the next, the first and the last beyond it).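

In this assay, among these compounds, 4-chloro-3-(trifluoromethyl)phenyl in place of (3-(trifluoromethyl)phenyl)amino on the carbonyl carbon gives a 2.4-fold higher number from compound 2 to compound 3 (0.39 log units; beyond the scatter), the first step to clear the scatter, modest in size and toward weaker inhibition of growth. Chloro in place of hydrogen on the aryl amide ring gives only a 1.4-fold higher number from compound 1 to compound 3 (0.14 log units; within the scatter), and the amide-to-urea step gives a 1.8-fold lower number from compound 1 to compound 2 (0.25 log units; within the scatter), so neither change read alone clears the scatter, and only the combined change does, between the two ends of the series. No measurement on hand explains this step.

The compounds shown leave open whether the 4-chloro-3-(trifluoromethyl)phenyl group on the urea of compound 2 would stay level with compound 2 or follow compound 3, which would separate the contribution of the chloro from that of the linking group. Also open, going by these compounds, is how this place responds to groups of another kind, such as a dimethylamino group or a carboxylic acid in place of the chloro, since chloro and hydrogen are the only two substituents compared there.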